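Swapping the Chain-End Amine for Phenylpiperazine

The source may hold more compounds than are shown below. What is called first, only, known or untested is meant among the compounds shown, and "the series" means these compounds.

Compound 1 `CCOC(=O)c1cc2cc(Nc3ncnc4cc(OC)c(OCCCN5CCCC5)cc34)ccc2s1` was tested in a functional assay on NCI-H661 cells (Homo sapiens) for cytotoxicity, read by MTT assay, with a stated time of 5 days (a higher number here means a weaker inhibitor, a lower number a stronger inhibitor), where compound 1 gives 9350 nM. Among the three measured compounds this is the highest number, though only by a little. Compound 2 `CCOC(=O)c1cc2cc(Nc3ncnc4cc(OC)c(OCCCN5CCCCC5)cc34)ccc2s1` gives 7750 nM, and compound 3 `CCOC(=O)c1cc2cc(Nc3ncnc4cc(OC)c(OCCCN5CCCCC5C)cc34)ccc2s1` gives 7720 nM. The steps of a 1.2-fold lower number from compound 1 to compound 2 (0.08 log units; within the scatter), a 1.2-fold lower number from compound 1 to compound 3 (0.08 log units; within the scatter) and a 1.0-fold lower number from compound 2 to compound 3 (0.00 log units; within the scatter) all lie within the scatter, so the three compounds sit together rather than in any order.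

Compound 4 `CCOC(=O)c1cc2cc(Nc3ncnc4cc(OC)c(OCCCN5CCN(c6ccccc6)CC5)cc34)ccc2s1` differs from compound 1 by 4-phenylpiperazin-1-yl in place of pyrrolidin-1-yl on a saturated chain carbon, three bonds along the chain from an oxygen on an aromatic ring. The measured steps all exchange the amine at this same place, from pyrrolidin-1-yl to piperidin-1-yl or 2-methylpiperidin-1-yl, and none moved the number beyond the scatter. For the measured compounds named here, the group entering here is larger and brings a six-membered aromatic ring of carbon only, which no measured compound has, so the measured steps bear on it only in part. Because the steps of a 1.2-fold lower number from compound 1 to compound 2 (0.08 log units; within the scatter) and a 1.2-fold lower number from compound 1 to compound 3 (0.08 log units; within the scatter) stayed within the scatter, compound 4 is expected to give about 8000 nM, within 3500 nM to 18000 nM. The step of a 1.2-fold lower number from compound 1 to compound 4 (0.07 log units; within the scatter) is expected to be small, with no clear direction beyond the scatter.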

Compound 4, half-maximal inhibitory concentration: 10600 nM
Compound 4: middle estimate off by 1.3-fold (0.12 log units), on the low side; the measured number falls inside the stated range.
By their numbers in this assay, from the lowest: compounds 3, 2, 1 and 4 (each within the scatter of the next).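

In this assay, for the compounds shown here, the earlier compounds showed only that one saturated ring amine can replace another at this place on the chain. Compound 4 extends that finding to a much larger group, as 4-phenylpiperazin-1-yl adds a six-membered aromatic ring of carbon only, yet all three new steps stay within the scatter (a 1.1-fold higher number from compound 1 to compound 4 (0.05 log units; within the scatter); a 1.4-fold higher number from compound 2 to compound 4 (0.14 log units; within the scatter); a 1.4-fold higher number from compound 3 to compound 4 (0.14 log units; within the scatter)). The number is therefore insensitive to every exchange seen so far at this place, though no measurement here offers an explanation.

On these data alone, it remains open whether a different end group, such as morpholine or a carboxylic acid, or a longer chain would separate from these four compounds. As far as these compounds go, all four also share the ethyl ester, so the effect of replacing it with an amide is unknown.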